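The compounds below may be only part of what the source reports. "The series", "measured", "known", "first", "only" and "open" are said of these compounds alone.

Measured in a functional assay on HCT-116 cells (Homo sapiens) for inhibition, read by colorimetric assay, with a stated time of 3 days; on this read-out higher numbers stand for weaker inhibition and lower numbers for stronger inhibition:
Compound 1 `O=C(CCCCCCNC(=O)C(O)(O)C(F)(F)F)Nc1ccccc1Br`: 14500 nM
Compound 2 `C/C(=N\O)C(=O)NCCCCCC(=O)Nc1ccccc1`: > 100000 nM
Compound 3 `O=C(CCCCCCNC(=O)C(O)(O)C(F)(F)F)Nc1c(F)cc(F)cc1F`: 22200 nM

Compound 2 has no number, only a limit, and stands at the limit of > 100000 nM in this assay, at which 1 of the 3 values shown sits. Compound 4 `CC(C)(C)C(O)(O)C(=O)NCCCCCC(=O)Nc1ccccc1` has not been measured and differs from compound 2 in one place: a group of 7 heavy atoms (5 carbon, 2 oxygen; no ring) in place of a group of 4 heavy atoms (2 carbon, 1 nitrogen, 1 oxygen; no ring), on a carbonyl carbon. For the measured compounds named here, the one measured step, a 1.5-fold higher number from compound 1 to compound 3 (0.18 log units; within the scatter), concerns a group on an amide-type nitrogen rather than this carbonyl carbon, so it gives no size for the present change. With no closer guide, only a modest move toward a lower number in this assay is expected, and a limit may be reported again. The expected step is an at least 1.6-fold lower number from compound 2 to compound 4 (0.22 log units; that floor lies within the scatter). Compound 4 is estimated at 60000 nM, with an expected range of 20000 nM to 130000 nM.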

Compound 4, half-maximal inhibitory concentration: 54400 nM
Estimate against measurement, compound 4: 1.1-fold (0.04 log units) above; the measured number falls inside the stated range.
By their numbers in this assay, from the lowest: compounds 1 and 3 (each within the scatter of the next); then compound 4. At a limit, above all of these: compound 2.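

In this assay, placing 1,1-dihydroxy-2,2-dimethylpropyl on this carbonyl carbon gives an at least 1.8-fold lower number from compound 2 to compound 4 (0.26 log units; that floor lies within the scatter). From the compounds shown here alone, compound 2 has a limit rather than a number: the limit of > 100000 nM in this assay, at which 1 of the 4 values shown sits. Compound 4 therefore gives this position its first measured number, but the true size of the step remains unknown, since its floor lies within the scatter.

Going by these compounds, what an amine or a carboxylic acid would give on this carbonyl carbon remains open. Compound 1 and compound 3 differ from compound 4 in more than one place, so they cannot settle how these groups compare.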